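Swapping a Methyl for Isopropyl on a Quinone Core

The compounds below may be only part of what the source reports. "The series", "measured", "known", "first", "only" and "open" are said of these compounds alone.

Measured compounds:
- compound 1, `CC1=C(N2CC2)C(=O)C(C(C)C)=C(N2CC2)C1=O`: 5.6
- compound 2, `CC1=C(N2CC2)C(=O)C(C(C)COC(N)=O)=C(N2CC2)C1=O`: 6.41
- compound 3, `CC1=C(N2CC2)C(=O)C(N2CC2)=C(N2CC2)C1=O`: 6.77

All three were tested in a functional assay on L1210 cells (Mus musculus), with a stated time of 12 days; on this read-out higher numbers stand for higher potency (the scale is a negative logarithm) and lower numbers for lower potency. Compound 1 stands lowest of the three: compound 2 lies a number 0.81 log units higher from compound 1 to compound 2 (beyond the scatter), and compound 3 lies a number 1.17 log units higher from compound 1 to compound 3 (beyond the scatter). Between the two higher compounds, the read-out moves a number 0.36 log units higher from compound 2 to compound 3 (beyond the scatter).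

Compound 4, `CC(C)C1=C(N2CC2)C(=O)C(C(C)C)=C(N2CC2)C1=O`, differs from compound 1 in one place: isopropyl in place of methyl on a double-bonded ring carbon. A methyl group leaves and an isopropyl group enters, on a double-bonded ring carbon of the shared core.

Within the data shown here, none of the measured steps tests this exact change. The step from compound 1 to compound 2 adds a carbamoyloxy group to a saturated chain carbon, and the step from compound 1 to compound 3 replaces the isopropyl group with aziridin-1-yl; both gains came from introducing a new kind of group, not from enlarging a carbon substituent. Among the measured compounds shown here, with no direct precedent, the expectation is a step of a number 0.10 log units lower from compound 1 to compound 4 (within the scatter), that is, nothing clearly beyond the scatter. Compound 4 is therefore estimated at 5.5, with a range from 4.9 to 6.1.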

Compound 4, logarithm of the reciprocal of the active concentration, log(1/C): 4.77
Compound 4: the middle estimate sits 0.73 log units above what was measured, and the stated range ends above it.
By their numbers in this assay, from the lowest: compound 4; then compound 1; then compound 2; then compound 3.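

In this assay, isopropyl in place of methyl on this double-bonded ring carbon gives a number 0.83 log units lower from compound 1 to compound 4 (beyond the scatter), so the change of a small carbon group here is enough to move the read-out. Among these compounds, the earlier steps from compound 1 all went upward and all changed the group at the ring atom three ring bonds away, the one bearing isopropyl; this step is the first to touch the methyl-bearing carbon, and the first from compound 1 to go downward. Nothing measured here gives a reason for this drop.

With only methyl and isopropyl shown at this carbon, it stays open whether the read-out falls steadily as the carbon group grows or whether isopropyl is a special case; an ethyl group, a plain hydrogen or an amine at the same carbon would help to tell these apart. On these data alone, it also stays open whether the same swap would lower the read-out on compound 2 or compound 3, whose other ring carbon bears a different group.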